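From a nitrile chain to an oxolane ring

A few compounds are considered here, and "the series" means these few. Any claim that something is new, unique, unknown or untested is made for them only; others in the source may bear on it.

In a functional assay on HT-29 cells (Homo sapiens) for inhibition, read by luminescence and CellTiter-Glo, with a stated time of 24 h (on this read-out lower numbers stand for an effect already at smaller amounts and higher numbers for an effect only at larger amounts of compound), three compounds sharing one core have been measured. Compound 1 (`CC(C)Cn1nc(C(=O)N[C@H]2COc3ccccc3N(C)C2=S)nc1Cc1ccccc1`) gives 1230 nM, compound 2 (`CN1C(=S)[C@@H](NC(=O)c2nc(Cc3ccccc3)n(CCCO)n2)COc2ccccc21`) gives 209 nM and compound 3 (`CN1C(=S)[C@@H](NC(=O)c2nc(Cc3ccccc3)n(CCCC#N)n2)COc2ccccc21`) gives 2400 nM. Two steps place the last of these numbers: a 2.0-fold higher number from compound 1 to compound 3 (0.29 log units; within the scatter), and an 11-fold higher number from compound 2 to compound 3 (1.06 log units; beyond the scatter). Compound 3 therefore stands level with one neighbour and well apart from the other.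

Compound 4 (`CN1C(=S)[C@@H](NC(=O)c2nc(Cc3ccccc3)n(C3CCOC3)n2)COc2ccccc21`) has oxolan-3-yl in place of 3-cyanopropyl on an aromatic nitrogen. Going by the values given here, no measured compound carries a ring at this place, so the evidence is indirect. The chain steps show that a change here can matter a great deal, as in an 11-fold higher number from compound 2 to compound 3 (1.06 log units; beyond the scatter), or stay within the scatter, as in a 2.0-fold higher number from compound 1 to compound 3 (0.29 log units; within the scatter). Compound 4 loses the nitrile and gains a ring oxygen, though not the hydroxy of compound 2 at 209 nM. A modest fall in the number is expected, smaller than the largest measured step and uncertain in size. The expected change is a 4.0-fold lower number from compound 3 to compound 4 (0.60 log units; beyond the scatter). For compound 4 the estimate is 600 nM, with an expected range of 170 nM to 2000 nM.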

Compound 4, half-maximal effective concentration: 1580 nM
Beside the measured number, compound 4's estimate is 2.6-fold (0.42 log units) below it; measured number inside the range.
By their numbers in this assay, from the lowest: compound 2; then compounds 1, 4 and 3 (each within the scatter of the next).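

In this assay, going by these compounds alone, a ring on the aromatic nitrogen appears for the first time, and it leaves compound 4 level with the open-chain compounds: a 1.5-fold lower number from compound 3 to compound 4 (0.18 log units; within the scatter) and a 1.3-fold higher number from compound 1 to compound 4 (0.11 log units; within the scatter) both lie within the scatter. Replacing an open chain with oxolan-3-yl at this position therefore makes no readable difference here, even though the nitrile is gone and the ring brings an oxygen. Compound 2 remains the only one of the four set apart, with a 7.6-fold higher number from compound 2 to compound 4 (0.88 log units; beyond the scatter) beyond the scatter, so a ring oxygen in oxolan-3-yl does not reproduce what the 3-hydroxypropyl chain shows, and the leaving and entering groups in the step from compound 3 have the same counts of hydrogen-bond donors and acceptors.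

No measurement is available that accounts for the separate position of compound 2. From the compounds shown here alone, it remains open whether that position depends on the hydroxy group itself or on its place along the chain, which a longer chain ending in hydroxy, a propyl chain ending in an amine or an oxolane ring bearing a hydroxy group would test.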